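The source may hold more compounds than are shown below. What is called first, only, known or untested is meant among the compounds shown, and "the series" means these compounds.

Measured so far:
compound 1 `CCc1cnc2c(C#N)c(N3CCC(c4ccccc4)CC3)ccn12` — 225%
compound 2 `CCc1nnc2c(C#N)c(N3CCC(c4ccccc4)CC3)ccn12` — 247%

In a functional assay on CHO cells for positive allosteric modulation of metabotropic glutamate receptor 2 (Homo sapiens), read by GTPgammaS binding, with a stated time of 30 min (on this read-out lower numbers stand for smaller maximal responses and higher numbers for larger maximal responses), compound 2 gives 247%, the highest of the two numbers recorded. Compound 1, which shares the piperidine and nitrile parts but carries a different core, gives 225%, and the gap between the two lies beyond the usual scatter of this assay.

Compound 3 `CC(C)(C)c1nnc2c(C#N)c(N3CCC(c4ccccc4)CC3)ccn12` has not yet been measured. It differs from compound 2 in a single change: tert-butyl in place of ethyl on an aromatic carbon. For the measured compounds named here, no step of this kind has been measured, so the expected effect rests only on the size of the change itself. A modest step is expected, either way or none beyond the scatter, with a slightly lower figure somewhat more likely. The estimate for compound 3 in this assay is 230%, with a range from 180% to 275%, meaning an expected step of a number 17 percentage points lower from compound 2 to compound 3 (beyond the scatter).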

Compound 3, largest response reached (Emax), in percent of the reference or control that the assay uses: 207%
Estimate against measurement, compound 3: 23 percentage points above; the range from low to high includes it.
By their numbers in this assay, from the lowest: compound 3; then compound 1; then compound 2.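

In this assay, for the compounds shown here, the aromatic carbon between two ring nitrogen atoms proves sensitive to the group it carries: swapping ethyl for tert-butyl gives a number 40 percentage points lower from compound 2 to compound 3 (beyond the scatter) and this is the only step that isolates a change at this position. Going from 2 to 4 heavy atoms, both carbon, with no ring, donor, acceptor or charge entering, is thus enough to shift the maximal response, although compound 3 still reaches 207% in this assay here. No supporting measurement is available to explain this step.

From the compounds shown here alone, with only ethyl and tert-butyl compared here, it remains open whether methyl, a longer chain such as n-propyl or a cyclopropyl ring would fall between them or outside their range. Going by these compounds, it is also open whether the same exchange would have a similar effect on the core of compound 1.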